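From nitro to iodo on an aromatic carbon

This account rests on a few compounds, and the source may have more. Where it says the series, first, only, none or still open, it means among the compounds named here.

Of the compounds shown here, two have numbers so far in an ADME assay on HUVEC cells (Homo sapiens) for cytotoxicity, read by MTT assay, with a stated time of 72 h; a lower number here means a stronger inhibitor, a higher number a weaker inhibitor. Compound 1 `C=C1CC[C@H]2C(C)(C)CCC[C@]2(C)[C@H]1CCC(C)CC(=O)O` gives 168000 nM. Going by the values given here, compound 2 `CC(CC[C@H]1/C(=C/c2ccc([N+](=O)[O-])cc2)CC[C@H]2C(C)(C)CCC[C@]12C)CC(=O)O` gives 194000 nM, a value within the scatter of the one for compound 1, so the two cannot be told apart on these data.

Compound 3 `CC(CC[C@H]1/C(=C/c2ccc(I)cc2)CC[C@H]2C(C)(C)CCC[C@]12C)CC(=O)O` has not yet been measured. It keeps the structure of compound 2 except at one place, para to a large group: iodo in place of nitro on an aromatic carbon. The 4-nitrophenyl thus becomes 4-iodophenyl. Among the compounds with values here, no measured pair shows what this exchange does, so the data offer no direction for it.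

The expectation rests on compound 2 at 194000 nM as the starting point, and no step beyond the scatter is expected in this assay. The estimate amounts to a 1.2-fold lower number from compound 2 to compound 3 (0.08 log units; within the scatter), an expected change that stays within the scatter. For compound 3 the expected value is 160000 nM, with an estimated range from 70000 nM to 320000 nM.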

Compound 3, half-maximal inhibitory concentration: 100000 nM
Compound 3: the middle estimate sits 1.6-fold (0.20 log units) above what was measured; measured number inside the range.
By their numbers in this assay, from the lowest: compounds 3, 1 and 2 (each within the scatter of the next).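

In this assay, going by these compounds alone, this pair gives the first reading of an exchange at this aromatic carbon, para to a large group: iodo in place of nitro amounts to a 1.9-fold lower number from compound 2 to compound 3 (0.29 log units; within the scatter), so compound 2 and compound 3 cannot be told apart on these data. The exchange replaces nitro, with 3 heavy atoms and 2 hydrogen-bond acceptors, with iodo, with 1 heavy atom and 0 hydrogen-bond acceptors, and this difference in the group does not produce a step beyond the scatter in this one pair. No measurement on hand accounts for the size of the step or links it to either group.

The compounds shown leave open whether an amine, a methoxy group or a fluoro group on this same aromatic carbon would give a step beyond the scatter from compound 2, or whether such groups would also stay within it. They also leave open what iodo would give on another carbon of the same aromatic ring, since only this one place appears in the pair.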